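The source may hold more compounds than are shown below. What is called first, only, known or untested is meant among the compounds shown, and "the series" means these compounds.

Measured in a functional assay on DU-145 cells (Homo sapiens) for cytotoxicity, read by trypan blue exclusion, with a stated time of 96 h; on this read-out lower numbers stand for stronger inhibition and higher numbers for weaker inhibition:
- Compound 1 `COc1cc(OC)c(/C=C/S(=O)(=O)Cc2ccc(F)c(N)c2)c(OC)c1`: 2500 nM
- Compound 2 `COc1ccc(N)cc1CS(=O)(=O)/C=C/c1c(OC)cccc1OC`: 25000 nM
- Compound 3 `COc1cc(OC)c(/C=C/S(=O)(=O)Cc2ccc(OC)cc2[N+](=O)[O-])c(OC)c1`: 20000 nM

Compound 2 sits at the high end of these numbers together with compound 3, and the two lie within the scatter of each other. Compound 1 has a lower number than compound 2, by a margin beyond the scatter.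

Compound 4 `COc1cc(OC)c(/C=C/S(=O)(=O)Cc2cc(N)ccc2OC)c(OC)c1` has not yet been measured. It comes from compound 2 by one change, methoxy in place of hydrogen on an aromatic carbon.

For the measured compounds named here, no step between measured compounds isolates this change, so the evidence is indirect. Compound 1 also carries this methoxy and gives 2500 nM, but it differs elsewhere as well. Compound 3 carries it too and gives 20000 nM, which goes against any simple reading, so the range must stay wide. On balance, a move toward lower numbers in this assay, beyond the scatter, seems more likely than no change. The expected size is a 6.3-fold lower number from compound 2 to compound 4 (0.80 log units; beyond the scatter), an estimate that remains uncertain.

For compound 4 the estimated value is 4000 nM, with an expected range from 700 nM to 20000 nM.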

Compound 4, half-maximal inhibitory concentration: 7500 nM
Beside the measured number, compound 4's estimate is 1.9-fold (0.27 log units) below it; measured number inside the range.
By their numbers in this assay, from the lowest: compound 1; then compound 4; then compounds 3 and 2 (each within the scatter of the next).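

In this assay, for the compounds shown here, methoxy in place of hydrogen on an aromatic carbon, meta to two methoxy groups and para to a large group, gives a 3.3-fold lower number from compound 2 to compound 4 (0.52 log units; beyond the scatter) as a modest step, and this pair provides the only direct reading of the change, which the earlier compounds could show only indirectly. The added methoxy does not bring compound 4 level with compound 1: 5-amino-2-methoxyphenyl in place of 3-amino-4-fluorophenyl on a saturated chain carbon bound to a sulfonyl sulfur gives a 3.0-fold higher number from compound 1 to compound 4 (0.48 log units; beyond the scatter) as a second modest step, so the choice of this aromatic group still matters in this series. No measurement shown here gives a cause for either step.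

The compounds shown leave open whether a hydroxyl group, an ethoxy group or a chlorine atom on the same aromatic carbon would move the number as methoxy does. Going by these compounds, the methoxy step also rests on a single pair, so whether it holds for an analogue of compound 3 that carries the nitro group remains unknown.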